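Moving the trifluoromethyl group on the phenyl substituent

The source may report more compounds than this note shows. Statements on the series, on what has been measured and on what is new or still open speak of the compounds shown alone.

For the measured compounds named here, in a functional assay on HeLa cells (Homo sapiens) for inhibition (a higher number here means a weaker inhibitor, a lower number a stronger inhibitor), compound 2 `Oc1ccc(-c2cc(-c3ccccc3C(F)(F)F)cc(-c3ccccc3O)n2)cc1` gives 16500 nM, the only true number so far. Compound 1 `Oc1ccc(-c2cc(-c3ccc(F)cc3)cc(-c3ccccc3O)n2)cc1` gives > 50000 nM, which is a limit of the assay and not a number.

Compound 3 `Oc1ccc(-c2cc(-c3ccc(C(F)(F)F)cc3)cc(-c3ccccc3O)n2)cc1` has 4-(trifluoromethyl)phenyl in place of the 2-(trifluoromethyl)phenyl of compound 2, opposite the ring nitrogen: 4-(trifluoromethyl)phenyl in place of 2-(trifluoromethyl)phenyl on an aromatic carbon.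

Going by the values given here, one measured step bears on this change: an at least 3.0-fold lower number from compound 1 to compound 2 (0.48 log units; beyond the scatter). That step changed both the group and its place, so it cannot separate the two. Compound 3 pairs the trifluoromethyl of compound 2 with a 4-substituted phenyl like the 4-fluorophenyl of compound 1. A small step towards a higher number in this assay is therefore expected, near the edge of the scatter. A reading at a limit also remains possible for compound 3: the limit of > 50000 nM in this assay, at which 1 of the 2 values shown sits.

The expected change is a 1.8-fold higher number from compound 2 to compound 3 (0.26 log units; within the scatter). The estimate for compound 3 is 30000 nM, with an expected range of 12000 nM to 50000 nM.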

Compound 3, half-maximal inhibitory concentration: > 50000 nM
Compound 3 ended at the assay's limit; the forecaster's own chance of this, stated with the estimate: 40%; at least 1.6-fold (0.22 log units) between middle value and limit.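

In this assay, 4-(trifluoromethyl)phenyl in place of 2-(trifluoromethyl)phenyl opposite the ring nitrogen gives an at least 3.0-fold higher number from compound 2 to compound 3 (0.48 log units; beyond the scatter). The two groups hold the same atoms, joined differently, so this step reads the place of the trifluoromethyl on the phenyl alone; the earlier step from 4-fluorophenyl to 2-(trifluoromethyl)phenyl changed group and place together and could not separate them. Within these three compounds, the only true number belongs to the compound with 2-(trifluoromethyl)phenyl, while compound 3 gives > 50000 nM, which is a limit of the assay and not a number, and it joins compound 1 at that same limit: the limit of > 50000 nM in this assay, at which 2 of the 3 values shown sit.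

The step from compound 1 to compound 3 cannot be read, both ends being limits, so 4-fluorophenyl and 4-(trifluoromethyl)phenyl stay unranked against each other. From the compounds shown here alone, it also stays open whether the lower number of compound 2 depends on trifluoromethyl itself or would hold for a methyl, a chlorine or an amine in the same place on the phenyl.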